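A few compounds are considered here, and "the series" means these few. Any claim that something is new, unique, unknown or untested is made for them only; others in the source may bear on it.

Measured compounds in a functional assay, read by spectrophotometry, with a stated time of 1 h; on this read-out higher numbers stand for weaker inhibition and lower numbers for stronger inhibition:
Compound 1, `N/N=C\c1cc(=O)oc2cc(OCc3ccccc3)cc(OCc3ccccc3)c12`, gives > 2000000 nM, and this is a limit of the assay rather than a number.
Compound 2, `O=c1cc(/C=N\O)c2c(OCc3ccccc3)cc(OCc3ccccc3)cc2o1`, gives "not active" (no number reported) in this assay.
Compound 3, `N/N=C\c1cc(=O)oc2cc(OCc3ccccc3)ccc12`, gives "not active" (no number reported) in this assay.

Compound 2 therefore stands without a single number: its entry in this assay reads as inactive, and the same is true of compound 3. Compound 1 is reported only as a limit, the one noted as the limit of > 2000000 nM in this assay, at which 1 of the 3 values shown sits. None of the three measured compounds gives a figure from which a trend could be drawn.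

The compound that follows is compound 4, `Nc1ccccc1/N=C\c1cc(=O)oc2cc(OCc3ccccc3)cc(OCc3ccccc3)c12`. It differs from compound 2 by 2-aminophenyl in place of hydroxy on a double-bonded nitrogen. Among the compounds with values here, no step between measured compounds is available here, so neither the size nor the direction of the change in this assay can be read from the data. The account rests instead on where compound 2 stands: since compound 2 shows "not active" (no number reported) in this assay, the expectation for compound 4 is a weak result as well, with no confident shift beyond the usual scatter in either direction. Compound 4 is thus estimated at 1000000 nM in this assay, with a range from 50000 nM to 5000000 nM, and it is quite possible that only a limit will be reported.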

Compound 4, half-maximal inhibitory concentration: 624000 nM
For compound 4 the middle estimate is 1.6-fold (0.20 log units) above the measured one; measured number inside the range.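

Within the data shown here, on a double-bonded nitrogen, putting 2-aminophenyl in place of amino gives the first step that can be read in this set: in this assay there is an at least 3.2-fold lower number from compound 1 to compound 4 (0.50 log units; beyond the scatter). Among these compounds, this shows that the position can carry a six-membered aromatic ring of carbon only while inhibition remains measurable, which the earlier compounds, with amino or hydroxy at this place, could not show because none of them gave a number. The entry for compound 1 is a limit and not a number, so the step fixes only a minimum size and not the full one: the limit of > 2000000 nM in this assay, at which 1 of the 4 values shown sits.

Among the compounds shown here, compound 2 reads as "not active", so no step from it can be read, and how hydroxy compares with 2-aminophenyl stays unsized. The compounds shown leave open whether the change depends on the aromatic ring alone or also on its amine, which a plain phenyl group or a carboxylic acid on that ring would separate, and whether 2-aminophenyl would give a number on the core of compound 3.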